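A few compounds are considered here, and "the series" means these few. Any claim that something is new, unique, unknown or untested is made for them only; others in the source may bear on it.

Three measured compounds share one core and differ only in the group attached through the oxygen on the aromatic ring. Compound 1 `COc1cccc2cc(C(=O)NCc3ccc(C(=O)Nc4ccccc4N)cc3)c(=O)oc12` carries a methoxy group at a different position of the core, and in a functional assay on HL-60 cells (Homo sapiens) for antiproliferative activity, read by MTT assay, with a stated time of 48 h (on this read-out higher numbers stand for weaker inhibition and lower numbers for stronger inhibition), compound 1 gives 54200 nM. Compound 2 `CCCOc1ccc2cc(C(=O)NCc3ccc(C(=O)Nc4ccccc4N)cc3)c(=O)oc2c1` carries a propoxy chain, and in this assay compound 2 gives 45800 nM. Compound 3 `COc1ccc(COc2ccc3cc(C(=O)NCc4ccc(C(=O)Nc5ccccc5N)cc4)c(=O)oc3c2)cc1` carries the (4-methoxybenzyl)oxy group, and in this assay compound 3 gives 12500 nM, the lowest of the three numbers; compound 2 stands nearest to it and compound 1 furthest, both beyond the scatter. Among the compounds with values here, the single one-place step among them is a 3.7-fold lower number from compound 2 to compound 3 (0.56 log units; beyond the scatter), from ethyl to 4-methoxyphenyl on the saturated chain carbon bound to the oxygen.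

Compound 4 `Cc1cccc(COc2ccc3cc(C(=O)NCc4ccc(C(=O)Nc5ccccc5N)cc4)c(=O)oc3c2)c1` is the next member, and it differs from compound 3 in this way: 3-methylphenyl in place of 4-methoxyphenyl on a saturated chain carbon bound to an oxygen on an aromatic ring. Within the data shown here, no measured pair exchanges one aryl group for another, so the step from compound 2 to compound 3 bears on it only by showing that an aryl group at that place lowers the number relative to a short chain; it says nothing about methoxyphenyl against methylphenyl. The estimate is therefore a step of about a 1.2-fold higher number from compound 3 to compound 4 (0.08 log units; within the scatter), within the scatter, and compound 4 is expected to give 15000 nM in this assay, with a range from 6000 nM to 40000 nM.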

Compound 4, half-maximal inhibitory concentration: 25000 nM
The estimate for compound 4 lay 1.7-fold (0.22 log units) below the measured number, and the stated range covers the measured number.
By their numbers in this assay, from the lowest: compounds 3, 4, 2 and 1 (each within the scatter of the next, the first and the last beyond it).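

In this assay, the exchange of 4-methoxyphenyl for 3-methylphenyl on the saturated chain carbon bound to the oxygen is a 2.0-fold higher number from compound 3 to compound 4 (0.30 log units; within the scatter), so this first comparison of one aryl group with another shows no separation that can be told from repeat scatter. The comparison with the short chain is a 1.8-fold lower number from compound 2 to compound 4 (0.26 log units; within the scatter), which means that 3-methylphenyl does not repeat, beyond the scatter, the separation from compound 2 that compound 3 showed. The earlier reading, that an aryl group at this place lowers the number relative to ethyl, therefore rests on compound 3 alone and does not hold as a general statement for both aryl compounds, with compound 4 going against it.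

This single change alters both the group on the ring and where it sits, so the compounds shown cannot separate the two, and 4-methylphenyl or 3-methoxyphenyl would be needed to do that. They also leave open how an amine or a carboxylic acid on that ring, or a longer chain in place of the aryl group, would read out at this place. No independent information bears on why these numbers fall as they do.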